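The source may report more compounds than this note shows. Statements on the series, on what has been measured and on what is new or still open speak of the compounds shown alone.

Compound 2 `COc1cc(-c2nnc3n2NC(c2ccco2)C(C(=O)c2cccc(Br)c2)S3)cc(OC)c1OC` carries a 3-bromophenyl on a carbonyl carbon whose other neighbour is a saturated ring carbon. Going by the values given here, in a functional assay on PC-3 cells (Homo sapiens) for cytotoxicity, read by MTT assay, with a stated time of 48 h (a higher number here means a weaker inhibitor, a lower number a stronger inhibitor), compound 2 gives 63900 nM, the highest of the two numbers measured so far; its only neighbour, compound 1 `COc1cc(-c2nnc3n2NC(c2ccco2)C(C(=O)c2ccc(F)c(F)c2)S3)cc(OC)c1OC`, gives 36000 nM in this assay, and the gap a 1.8-fold higher number from compound 1 to compound 2 (0.25 log units; within the scatter) lies within the scatter.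

Compound 3 `COc1cc(-c2nnc3n2NC(c2ccco2)C(C(=O)c2ccco2)S3)cc(OC)c1OC` differs from compound 2 by one change: furan-2-yl in place of 3-bromophenyl on a carbonyl carbon. Among the compounds with values here, the one measured step that bears on it is the exchange at the same carbonyl carbon a 1.8-fold higher number from compound 1 to compound 2 (0.25 log units; within the scatter), which swapped one six-membered aromatic ring for another and left the number within the scatter. Within the data shown here, no measured step shows what a five-membered aromatic ring with one hetero atom does at this place, so the expectation rests on that single exchange. From it, compound 3 is expected to show no step beyond the scatter, a 1.3-fold lower number from compound 2 to compound 3 (0.11 log units; within the scatter). Compound 3 is therefore estimated at 50000 nM in this assay, with a range from 15000 nM to 160000 nM.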

Compound 3, half-maximal inhibitory concentration: 58300 nM
For compound 3 the middle estimate is 1.2-fold (0.07 log units) below the measured one, within the range that was stated.
By their numbers in this assay, from the lowest: compounds 1, 3 and 2 (each within the scatter of the next).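

Going by these compounds alone, the carbonyl carbon whose other neighbour is a saturated ring carbon now carries a five-membered aromatic ring with 1 hetero atom, where the earlier compounds held only a six-membered aromatic ring of carbon only. In this assay furan-2-yl gives a 1.1-fold lower number from compound 2 to compound 3 (0.04 log units; within the scatter) when it replaces 3-bromophenyl and a 1.6-fold higher number from compound 1 to compound 3 (0.21 log units; within the scatter) when it replaces 3,4-difluorophenyl. Across these three compounds, then, neither the change of ring size, nor the loss of the halogen atoms, nor the entry of a hydrogen-bond acceptor moves the number beyond the scatter, and nothing measured here offers an explanation of that result.

Going by these compounds, all three compounds hold an aromatic ring at this carbonyl carbon, so it stays open whether an amine, a carboxylic acid or a longer alkyl chain in that place would give a step beyond the scatter. The rest of the core is the same throughout, which leaves open what a change elsewhere, such as replacing the furan-2-yl on the saturated ring carbon, would do to the number.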